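Three Bis-Benzylidene Cyclohexanones and a Catechol Analogue

The source may report more compounds than this note shows. Statements on the series, on what has been measured and on what is new or still open speak of the compounds shown alone.

compound 1 `COc1cc(/C=C2\CCC/C(=C\c3cccc(OC)c3OC)C2=O)cc(OC)c1` — 4500 nM
compound 2 `COc1cc(/C=C2\CCC/C(=C\c3cccc(OC)c3OC)C2=O)ccc1O` — 5900 nM
compound 3 `COc1ccc(/C=C2\CCC/C(=C\c3ccccc3Cl)C2=O)cc1OC` — 6800 nM

Of the compounds shown here, three sharing one core have been tested in a functional assay on HT-1080 cells (Homo sapiens) for cytotoxicity, read by MTT assay, with a stated time of 72 h; a lower number here means a stronger inhibitor, a higher number a weaker inhibitor. Compound 1 gives 4500 nM, compound 2 gives 5900 nM, and compound 3 gives 6800 nM. Compound 3 has the highest number of the three, but its gap to compound 2 and its gap to compound 1 both lie within the scatter of the measurement, so no order among the three can be claimed in this assay.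

Compound 4 `COc1ccc(/C=C2\CCC/C(=C\c3ccc(O)c(O)c3)C2=O)cc1OC` has not yet been measured. It differs from compound 3 in one place: 3,4-dihydroxyphenyl in place of 2-chlorophenyl on a double-bonded chain carbon bound to a double-bonded ring carbon. The change adds two hydrogen-bond donors and two hydrogen-bond acceptors where compound 3 carries none on that ring.

For the measured compounds named here, with no measured pair that isolates this change, the expectation rests only on the narrow spread of the three values. For compound 4 in this assay the step of a 1.2-fold lower number from compound 3 to compound 4 (0.09 log units; within the scatter) is expected to be small, at most a modest move toward a lower number and possibly none beyond the scatter. Compound 4 is therefore estimated at 5500 nM, with a likely range from 2000 nM to 15000 nM.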

Compound 4, half-maximal inhibitory concentration: 4200 nM
The estimate for compound 4 lay 1.3-fold (0.12 log units) above the measured number; the measured number falls inside the stated range.
By their numbers in this assay, from the lowest: compounds 4, 1, 2 and 3 (each within the scatter of the next).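

For the compounds shown here, compound 3 and compound 4 form the first pair in the set that differs in one place, so the effect of this exchange can now be read directly. In this assay, 3,4-dihydroxyphenyl in place of 2-chlorophenyl on a double-bonded chain carbon bound to a double-bonded ring carbon gives a 1.6-fold lower number from compound 3 to compound 4 (0.21 log units; within the scatter) and so does not separate the two groups. Adding 2 hydrogen-bond donors and 2 hydrogen-bond acceptors at this place therefore produces no readable change in this assay, and nothing available here bears on the reason.

As far as these compounds go, whether an amine or a carboxylic acid at this place would move the number beyond the scatter remains open. From the compounds shown here alone, it is also open whether a single hydroxyl would read like the 3,4-dihydroxyphenyl group.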